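This account rests on a few compounds, and the source may have more. Where it says the series, first, only, none or still open, it means among the compounds named here.

Compound 1, `O=C1O[C@H]([C@@H](O)Cn2cc(-c3cccc(O)c3)nn2)C(OCc2ccccc2)=C1OCc1ccccc1`, was tested in a functional assay on HeLa cells (Homo sapiens) for antiproliferative activity, read by MTT assay, with a stated time of 72 h (a lower number here means a stronger inhibitor, a higher number a weaker inhibitor), where compound 1 gives 39300 nM. Within the data shown here, its only measured companion is compound 2, `O=C1O[C@H]([C@@H](O)Cn2cc(CNS(=O)(=O)c3ccc(Cl)cc3F)nn2)C(OCc2ccccc2)=C1OCc1ccccc1`, which in this assay gives 20700 nM. Among the measured compounds shown here, the two numbers lie within the usual scatter of each other, so compound 1 cannot be set apart from compound 2 on this evidence, and no step between them is counted. Compound 3, `COc1ccc(-c2cn(C[C@H](O)[C@H]3OC(=O)C(OCc4ccccc4)=C3OCc3ccccc3)nn2)cc1`, shares the core of compound 1 and differs from it in one place: 4-methoxyphenyl in place of 3-hydroxyphenyl on an aromatic carbon. For the measured compounds named here, no measured pair shows what such an exchange does here, so the expectation rests on compound 1 alone. The step from compound 1 to compound 3 in this assay is expected to be a 1.1-fold lower number from compound 1 to compound 3 (0.05 log units; within the scatter), that is, no change beyond the scatter in either direction. Compound 3 is therefore estimated at 35000 nM, with a range from 12000 nM to 100000 nM.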

Compound 3, half-maximal inhibitory concentration: 16400 nM
Beside the measured number, compound 3's estimate is 2.1-fold (0.33 log units) above it; the measured number falls inside the stated range.
By their numbers in this assay, from the lowest: compounds 3, 2 and 1 (each within the scatter of the next, the first and the last beyond it).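

In this assay, among these compounds, putting 4-methoxyphenyl in place of 3-hydroxyphenyl on this aromatic carbon gives a 2.4-fold lower number from compound 1 to compound 3 (0.38 log units; beyond the scatter) and so provides the first step at this position that lies beyond the scatter, though a modest one. The position therefore does respond to the aryl group it carries, at least for this pair, where the entering group has 0 hydrogen-bond donors and the leaving group has 1. No measurement at hand speaks to what lies behind this step.

The compounds shown do not separate the place of the ring substituent from the exchange of hydroxy for methoxy, which 3-methoxyphenyl or 4-hydroxyphenyl on the same carbon could do. They also leave open how an unsubstituted phenyl, an aminophenyl or a carboxylic acid on the phenyl ring would fare here.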